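Alkyne aryl swaps on the shared core: compound 4

The source may report more compounds than this note shows. Statements on the series, on what has been measured and on what is new or still open speak of the compounds shown alone.

Measured so far in a functional assay on HEK293 cells for negative allosteric modulation of metabotropic glutamate receptor 5 (Homo sapiens), read by FLIPR and calcium flux; on this read-out lower numbers stand for stronger inhibition and higher numbers for weaker inhibition:
compound 1, `Cc1cccc(C#Cc2ccc3c(n2)CCN(C)C3=O)c1`, 2.9 nM
compound 2, `CN1CCc2nc(C#Cc3cccc(Cl)c3)ccc2C1=O`, 22 nM
compound 3, `CN1CCc2nc(C#Cc3ccc(Cl)cc3)ccc2C1=O`, 352 nM

Compound 3 gives the highest number of the three, with the steps of a 16-fold higher number from compound 2 to compound 3 (1.20 log units; beyond the scatter) and a 120-fold higher number from compound 1 to compound 3 (2.08 log units; beyond the scatter) both beyond the scatter. Compound 4, `CN1CCc2nc(C#Cc3ccccn3)ccc2C1=O`, carries the change (pyridin-2-yl in place of 4-chlorophenyl on a triple-bonded carbon). Going by the values given here, the steps that bear on it are those at the same triple-bonded carbon, a 120-fold higher number from compound 1 to compound 3 (2.08 log units; beyond the scatter) and a 16-fold higher number from compound 2 to compound 3 (1.20 log units; beyond the scatter), both large; they show that the aromatic ring at this position moves this assay strongly, and that compound 3 sits at the weak end. A large step downward from compound 3 is therefore expected, of the order of an 18-fold lower number from compound 3 to compound 4 (1.25 log units; beyond the scatter). For compound 4 the estimate in this assay is 20 nM, within 4 nM to 100 nM.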

Compound 4, half-maximal inhibitory concentration: 184 nM
Beside the measured number, compound 4's estimate is 9.2-fold (0.96 log units) below it; measured number above the stated range.
By their numbers in this assay, from the lowest: compound 1; then compound 2; then compounds 4 and 3 (each within the scatter of the next).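

In this assay the swap to pyridin-2-yl gives a 1.9-fold lower number from compound 3 to compound 4 (0.28 log units; within the scatter), so this ring and 4-chlorophenyl cannot be told apart at the triple-bonded carbon. Neither matches the earlier aromatic groups, with an 8.4-fold higher number from compound 2 to compound 4 (0.92 log units; beyond the scatter) and a 63-fold higher number from compound 1 to compound 4 (1.80 log units; beyond the scatter) leaving 3-chlorophenyl and 3-methylphenyl with the lower numbers. No measurement on hand accounts for these differences.

Still open, from the compounds shown here alone, is how an amine or a methoxy group on the aromatic ring at this carbon would read. Also open, going by these compounds, is whether a methyl group on the pyridin-2-yl ring would bring the number closer to that of compound 1.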